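The compounds below may be only part of what the source reports. "The series", "measured", "known", "first", "only" and "open" are said of these compounds alone.

Working notes on the series. Compound 1 `CCN(C(=O)CN(c1cc(N(C)C)ccc1Cl)S(=O)(=O)c1ccc(OC)c(OC)c1)c1cccc(C)n1` and compound 2 `CCN(C(=O)CN(c1cc(N(C)C)ccc1Cl)S(=O)(=O)c1ccc(OC)c(OC)c1)c1ccn(C)n1` share one core and differ only in the group on the amide-type nitrogen; in a functional assay on CHO cells for inhibition of Orexin receptor type 2 (Homo sapiens), read by FLIPR and calcium flux (a lower number here means a stronger inhibitor, a higher number a weaker inhibitor), compound 1 gives 5 nM and compound 2 gives 7 nM. Going by the values given here, the single measured step, a 1.4-fold higher number from compound 1 to compound 2 (0.15 log units; within the scatter), leaves the number where it was. Compound 3 `CCN(CC)C(=O)CN(c1ccc(C)cc1)S(=O)(=O)c1cccc(C)c1` rests on a simpler core; in this assay compound 3 gives 60 nM, the highest of the three numbers, beyond the scatter above compound 2 and further still above compound 1. Compound 4 `CCN(CC)C(=O)CN(c1ccc(C)cc1)S(=O)(=O)c1ccc(Br)cc1` differs from compound 3 in one place: 4-bromophenyl in place of 3-methylphenyl on a sulfonyl sulfur. Among the compounds with values here, no measured step touches the group on the sulfonyl sulfur; the only recorded step sits on the amide-type nitrogen, belongs to a different core, and gave no shift beyond the scatter, so it offers no direct guide for this change. With nothing comparable measured, for compound 4 the expected step is no change at the digits printed from compound 3 to compound 4 (within the scatter), which is taken as none beyond the scatter. In this assay compound 4 is therefore estimated at 60 nM, with a range from 20 nM to 200 nM.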

Compound 4, half-maximal inhibitory concentration: 142 nM
For compound 4 the middle estimate is 2.4-fold (0.37 log units) below the measured one; the range from low to high includes it.
By their numbers in this assay, from the lowest: compounds 1 and 2 (each within the scatter of the next); then compound 3; then compound 4.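

In this assay, going by these compounds alone, the group on the sulfonyl sulfur turns out to matter: 4-bromophenyl in place of 3-methylphenyl gives a 2.4-fold higher number from compound 3 to compound 4 (0.37 log units; beyond the scatter), the first step to lie beyond the scatter and the first to touch this position. The counts do not separate the two groups, since both have the same numbers of heavy atoms, hydrogen-bond donors and hydrogen-bond acceptors, both hold one six-membered aromatic ring of carbon only, and neither carries a net charge, so the shift goes with the identity of the substituent, its place on the ring, or both. Nothing available bears on the origin of this shift.

The compounds shown leave those two changes tied together: 4-methylphenyl or 3-bromophenyl on the sulfonyl sulfur would pull them apart, and a phenyl ring bearing an amine or a carboxylic acid would test how far this position tolerates a different kind of substituent. On these data alone, it also remains open whether the step carries over to the core of compound 1, where the sulfonyl sulfur bears a different group.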